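The source may hold more compounds than are shown below. What is called first, only, known or untested is meant among the compounds shown, and "the series" means these compounds.

Series in a functional assay on A549 cells (Homo sapiens) for antiproliferative activity, read by MTT assay, with a stated time of 24 h; a higher number here means a weaker inhibitor, a lower number a stronger inhibitor:

Compound 1 `O=c1[nH]cc(S(=O)(=O)Nc2ccccc2-c2cn(-c3ccccc3)nn2)c(=O)[nH]1` gives 6790 nM.
Compound 2 `O=c1[nH]cc(S(=O)(=O)Nc2ccccc2-c2cn(-c3ccccc3F)nn2)c(=O)[nH]1` gives 7370 nM.
Compound 3 `O=c1[nH]cc(S(=O)(=O)Nc2ccccc2-c2cn(-c3cccc(F)c3)nn2)c(=O)[nH]1` gives 8130 nM.

Compound 1 holds the lowest of the three numbers; the nearest is compound 2, at a 1.1-fold higher number from compound 1 to compound 2 (0.04 log units; within the scatter), and the furthest is compound 3, at a 1.2-fold higher number from compound 1 to compound 3 (0.08 log units; within the scatter). Both steps fall within the scatter, so none of the three can be called stronger or weaker than another. The step between the two fluoro analogues, a 1.1-fold higher number from compound 2 to compound 3 (0.04 log units; within the scatter), is likewise within the scatter.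

Compound 4 `O=c1[nH]cc(S(=O)(=O)Nc2ccccc2-c2cn(-c3cccc(Cl)c3)nn2)c(=O)[nH]1` has not been measured in this assay. It differs from compound 1 by chloro in place of hydrogen on an aromatic carbon, the group sitting meta to a large group. Among the measured compounds shown here, the steps that bear on this change are the two fluoro-for-hydrogen steps, a 1.1-fold higher number from compound 1 to compound 2 (0.04 log units; within the scatter) and a 1.2-fold higher number from compound 1 to compound 3 (0.08 log units; within the scatter), and the shift of the fluoro between positions, a 1.1-fold higher number from compound 2 to compound 3 (0.04 log units; within the scatter); each sat within the scatter. A single halogen at this position is therefore expected to leave the number essentially unchanged, with no step beyond the scatter in either direction, a 1.0-fold higher number from compound 1 to compound 4 (0.01 log units; within the scatter). The estimate for compound 4 in this assay is 7000 nM, with a range from 3500 nM to 14000 nM.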

Compound 4, half-maximal inhibitory concentration: 2340 nM
Compound 4: the middle estimate sits 3.0-fold (0.48 log units) above what was measured, outside the stated range (below it).
By their numbers in this assay, from the lowest: compound 4; then compounds 1, 2 and 3 (each within the scatter of the next).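

In this assay, among the compounds shown here, chloro on the phenyl ring, meta to a large group, gives the first step beyond the scatter (a 2.9-fold lower number from compound 1 to compound 4 (0.46 log units; beyond the scatter)). The identity of the halogen matters at this place: fluoro in place of hydrogen gave no step beyond the scatter, whereas chloro in place of fluoro does (a 3.5-fold lower number from compound 3 to compound 4 (0.54 log units; beyond the scatter)). The 3-chlorophenyl compound also separates from the 2-fluorophenyl analogue (a 3.1-fold lower number from compound 2 to compound 4 (0.50 log units; beyond the scatter)), although that pair differs in both halogen and place.

No measurement shown explains why chloro behaves differently from hydrogen or fluoro here.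

On these data alone, whether the trend continues with bromo, or with a methyl or trifluoromethyl group at the same place, remains open. The compounds shown also leave open how a methoxy group or a nitrile would read there.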